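This account rests on a few compounds, and the source may have more. Where it says the series, first, only, none or still open, it means among the compounds named here.

The series rests on a shared core carrying a carbamate on one side and a selenium-bearing group on the other. Compound 1 `CC(C)COC(=O)Nc1ccc([Se][Se]c2ccc(NC(=O)OCC(C)C)cc2)cc1` joins two such units through a diselenide; in a functional assay on HT-29 cells (Homo sapiens) for cytotoxicity, read by MTT assay, with a stated time of 72 h (on this read-out higher numbers stand for weaker inhibition of growth and lower numbers for stronger inhibition of growth), compound 1 gives 19900 nM. Compound 2 `CCCOC(=O)Nc1ccc([Se]C#N)cc1` carries a selenocyanate instead; in this assay compound 2 gives 28400 nM. Of the two values, that of compound 2 sits at the upper end, but compound 1 lies within the usual scatter of it, so the two are not told apart.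

Compound 3 `CCCCOC(=O)Nc1ccc([Se]C#N)cc1` differs from compound 2 by methyl in place of hydrogen on a saturated chain carbon, three bonds along the chain from an oxygen next to a carbonyl group, that is, propyl to butyl on the carbamate chain. Among the measured compounds shown here, no measured pair shows the effect of such a change here. Compound 3 is expected to stay close to compound 2, with the step of a 1.1-fold lower number from compound 2 to compound 3 (0.06 log units; within the scatter) expected to fall within the scatter, giving an estimate of 25000 nM with a range from 9000 nM to 70000 nM.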

Compound 3, concentration for 50% growth inhibition: 8100 nM
Compound 3: the middle estimate sits 3.1-fold (0.49 log units) above what was measured; the whole stated range lies above it.
By their numbers in this assay, from the lowest: compound 3; then compounds 1 and 2 (each within the scatter of the next).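

In this assay, among the compounds shown here, lengthening the carbamate chain from propyl to butyl gives a real difference, with a 3.5-fold lower number from compound 2 to compound 3 (0.54 log units; beyond the scatter) as the only step so far. It shows that this position, on a saturated chain carbon, three bonds along the chain from an oxygen next to a carbonyl group, is not silent: with the selenocyanate kept, one added methyl moves the number towards stronger inhibition of growth. Nothing available here accounts for this step, so its origin stays unexplained.

A single step leaves open whether a longer chain, such as pentyl or hexyl, would carry the change further, hold it or reverse it. As far as these compounds go, it is also open whether a phenyl group at the end of the chain would be tolerated, and whether butyl would have the same effect in a diselenide.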